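The source may report more compounds than this note shows. Statements on the series, on what has been measured and on what is new or still open speak of the compounds shown alone.

Two compounds sharing one core have been run in a functional assay on CHO-K1 cells for agonist activity at Glucose-dependent insulinotropic receptor (Homo sapiens), read by a luciferase reporter, with a stated time of 5 h; on this read-out higher numbers stand for an effect only at larger amounts of compound and lower numbers for an effect already at smaller amounts. Compound 1 `CC(C)(C)OC(=O)N1CCC(Oc2ncnc3c2CCN3c2ccc(S(C)(=O)=O)cc2F)CC1` carries a tert-butoxy group on the carbonyl carbon at the ring amine, and in this assay compound 1 gives 20 nM. Compound 2 `CCSC(=O)N1CCC(Oc2ncnc3c2CCN3c2ccc(S(C)(=O)=O)cc2F)CC1` carries an ethylsulfanyl group there instead, and in this assay compound 2 gives 31.6 nM. Among the compounds with values here, the single measured step, a 1.6-fold higher number from compound 1 to compound 2 (0.20 log units; within the scatter), is within the scatter, so compound 2 stands beside compound 1 with no difference that can be called real.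

Compound 3 `CS(=O)(=O)c1ccc(N2CCc3c(OC4CCN(C(=S)Sc5ccccc5)CC4)ncnc32)c(F)c1` is not yet measured. It differs from compound 2 by a group of 9 heavy atoms (7 carbon, 2 sulfur; one six-membered aromatic ring of carbon only) in place of a group of 5 heavy atoms (3 carbon, 1 oxygen, 1 sulfur; no ring), on an amine nitrogen in a ring. Within the data shown here, only the step from compound 1 to compound 2 bears on this change, and that step swapped one small group for another without moving the number beyond the scatter; the change to compound 3 is larger and brings in a six-membered aromatic ring of carbon only, which no measured step covers. Compound 3 is therefore expected to sit close to compound 2, with an estimated 1.3-fold higher number from compound 2 to compound 3 (0.10 log units; within the scatter) and no clear direction. The estimate for compound 3 in this assay is 40 nM, with a range from 12 nM to 150 nM.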

Compound 3, half-maximal effective concentration: 12.6 nM
Compound 3: the middle estimate sits 3.2-fold (0.50 log units) above what was measured; measured number inside the range.
By their numbers in this assay, from the lowest: compounds 3, 1 and 2 (each within the scatter of the next, the first and the last beyond it).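

In this assay, within the data shown here, the amine nitrogen in the six-membered ring accepts a group with a six-membered aromatic ring of carbon only, and the read-out moves by a 2.5-fold lower number from compound 2 to compound 3 (0.40 log units; beyond the scatter) with that change, the first step at this position that is not lost in the scatter, although it is modest. Set against the tert-butoxy group of compound 1, the same group gives a 1.6-fold lower number from compound 1 to compound 3 (0.20 log units; within the scatter) and so no difference that can be called real, which means that the larger group is tolerated here and that only compound 2 stands apart from compound 3. Nothing among the data offers an explanation for the step from compound 2.

The entering group differs from the ethylsulfanyl carbonyl in more than its aromatic ring, so the part played by the ring itself and the part played by the second sulfur cannot be separated on these compounds. From the compounds shown here alone, it also remains open how this position would respond to a benzyl group, to a pyridine ring in place of the carbon-only ring, or to a substituent such as chlorine on that ring.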